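This account rests on a few compounds, and the source may have more. Where it says the series, first, only, none or still open, it means among the compounds named here.

Measured so far:
compound 1 `COc1cc(OC)c(C(=O)/C=C/c2ccccc2SC)c(OC)c1`, 0.3%
compound 2 `COc1cc(OC)c(C(=O)/C=C/c2ccc(Cl)cc2)c(OC)c1`, 0.8%

In a functional assay on Huh-7 cells (Homo sapiens), read by fluorescence and BrdU incorporation, with a stated time of 48 h, tested at 25 uM (on this read-out lower numbers stand for a stronger effect and higher numbers for a weaker effect at the one concentration tested), compound 2 holds the highest of the two numbers. Its nearest neighbour is compound 1, separated by a number 0.5 percentage points higher from compound 1 to compound 2 (within the scatter), a gap within the scatter.

Compound 3 `COc1cc(OC)c(C(=O)/C=C/c2ccc(F)cc2)c(OC)c1` differs from compound 2 by fluoro in place of chloro on an aromatic carbon. Among the compounds with values here, the only measured step that bears on this exchange of one halogen for another on the aryl is a number 0.5 percentage points higher from compound 1 to compound 2 (within the scatter), itself within the scatter. A swap of one small aryl substituent for another has so far left the read-out flat.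

The step expected in this assay is therefore a number 0.2 percentage points higher from compound 2 to compound 3 (within the scatter), none beyond the scatter. Compound 3 is estimated at 1%, with a range from 0% to 10%.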

Compound 3, a percentage reported as activity, at one concentration (the size of the read-out at that concentration, not a potency): 1.1%
Estimate against measurement, compound 3: 0.1 percentage points below, and the stated range covers the measured number.
By their numbers in this assay, from the lowest: compounds 1, 2 and 3 (each within the scatter of the next).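

In this assay, fluoro in place of chloro on an aromatic carbon, para to a large group, gives a number 0.3 percentage points higher from compound 2 to compound 3 (within the scatter), so the two halogens cannot be told apart at this position. The exchange of 2-(methylsulfanyl)phenyl for 4-fluorophenyl gives a number 0.8 percentage points higher from compound 1 to compound 3 (within the scatter), so a second aryl exchange also yields no difference beyond the scatter. No measured evidence accompanies these numbers to account for them.

Open, as far as these compounds go, is whether an amine or a carboxylic acid at this aromatic carbon would give a step beyond the scatter. Also open, from the compounds shown here alone, is what a longer chain in place of the halogen would do.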